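This account rests on a few compounds, and the source may have more. Where it says the series, first, only, none or still open, it means among the compounds named here.

Three compounds have so far been measured in a functional assay on T-24 cells (Homo sapiens) for antiproliferative activity, read by MTT assay, with a stated time of 48 h; on this read-out higher numbers stand for weaker inhibition and lower numbers for stronger inhibition:

- compound 1 `COc1ccccc1NC(=O)Nc1cccc(CNc2nccnc2Cl)c1` gives 10400 nM
- compound 2 `Cc1ccc(NC(=O)Nc2cccc(CNc3nccnc3Cl)c2)c(C)c1` gives 9230 nM
- compound 3 `Cc1ccccc1NC(=O)Nc1cccc(CNc2nccnc2Cl)c1` gives 13600 nM

All three share the same core and differ only in the aryl group carried on the urea nitrogen. Compound 3 gives the highest of the three numbers, yet its distance to the other two is small: a 1.3-fold higher number from compound 1 to compound 3 (0.12 log units; within the scatter) and a 1.5-fold higher number from compound 2 to compound 3 (0.17 log units; within the scatter), both within the usual scatter, as is a 1.1-fold lower number from compound 1 to compound 2 (0.05 log units; within the scatter).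

The next compound, compound 4 `O=C(Nc1cccc(CNc2nccnc2Cl)c1)Nc1ccc(Cl)c(Cl)c1`, keeps that core and changes the aryl group once more: 3,4-dichlorophenyl in place of 2-methylphenyl on an amide-type nitrogen. For the measured compounds named here, no measured step so far involves a chlorine-bearing ring; the three known steps only swap methyl and methoxy groups on the aryl ring, and none of them moved the number beyond the scatter. There is therefore no basis in these data for expecting a shift in either direction. Compound 4 is expected to give about 12000 nM, with a range from 5000 nM to 30000 nM. For compound 4 the expected step is a 1.1-fold lower number from compound 3 to compound 4 (0.05 log units; within the scatter).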

Compound 4, half-maximal inhibitory concentration: 5210 nM
Compound 4: the middle estimate sits 2.3-fold (0.36 log units) above what was measured; the measured number falls inside the stated range.
By their numbers in this assay, from the lowest: compounds 4, 2, 1 and 3 (each within the scatter of the next, the first and the last beyond it).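

For the compounds shown here, on the urea nitrogen, 3,4-dichlorophenyl in place of 2-methylphenyl gives a 2.6-fold lower number from compound 3 to compound 4 (0.42 log units; beyond the scatter) in this assay, the first step at this place to pass the scatter, although only modestly. The same group in place of the other two aryl groups gives a 1.8-fold lower number from compound 2 to compound 4 (0.25 log units; within the scatter) and a 2.0-fold lower number from compound 1 to compound 4 (0.30 log units; within the scatter), so compound 4 stands clear of compound 3 alone and cannot be called the most potent of the four. Nothing available explains why this change of ring moves the number.

Compound 4 is the only compound shown with a chlorine-bearing aryl ring, which leaves open whether one chlorine alone would give a similar step and whether fluorine or bromine could take its place. Also open, on these data alone, is how an aryl ring carrying an amine or a carboxylic acid would read at this nitrogen.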